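The source may hold more compounds than are shown below. What is called first, only, known or untested is meant among the compounds shown, and "the series" means these compounds.

Measured compounds in the series:

Compound 1, `Cc1nc2ccccc2c(=O)n1NC(=O)Nc1ccc(Cl)cc1`, gives 300 mg/kg in a functional assay on the whole organism with Mus musculus as the target, in the maximal electroshock model, with a stated time of 0.5 h; a lower number here means that less compound is needed, a higher number that more compound is needed for the effect.
Compound 2, `Cc1nc2ccccc2c(=O)n1NC(=O)Nc1ccc(Br)cc1`, gives 300 mg/kg in this assay.

Compound 2 stands level with compound 1 at the digits shown: the only measured step, no change at the digits printed from compound 1 to compound 2 (within the scatter), lies within the scatter, so exchanging one halogen for another on the aromatic carbon left the minimum effective dose unchanged.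

Compound 3, `CCc1ccc(NC(=O)Nn2c(C)nc3ccccc3c2=O)cc1`, has not been tested in this assay. Its difference from compound 2 is ethyl in place of bromo on an aromatic carbon. For the measured compounds named here, no measured step covers an ethyl group at this carbon; the one step that bears on the position, the halogen exchange from compound 1 to compound 2, was flat. On that basis the step of no change at the digits printed from compound 2 to compound 3 (within the scatter) is expected to stay within the scatter, with no direction favoured. Compound 3 is therefore estimated at 300 mg/kg in this assay, with a range from 100 mg/kg to 600 mg/kg.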

Compound 3, minimum effective dose: 300 mg/kg
For compound 3 middle estimate and measured number coincide at the digits printed, and the stated range covers the measured number.
By their numbers in this assay, from the lowest: compounds 1, 2 and 3 (each within the scatter of the next).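

In this assay, the step of no change at the digits printed from compound 2 to compound 3 (within the scatter) carries the flat reading at this aromatic carbon, para to a large group, beyond a halogen exchange: an alkyl group, ethyl, now stands there in place of bromo. The step of no change at the digits printed from compound 1 to compound 3 (within the scatter) gives the same reading with ethyl in place of chloro, so chloro, bromo and ethyl cannot be told apart at this position in this assay. No measured evidence accounts for this flat reading.

As far as these compounds go, whether an amine, a carboxylic acid or a longer chain at this carbon would shift the minimum effective dose remains open. With all three compounds level, the series also gives no sign of what would move the read-out, either at this position or on the shared core.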